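The source may report more compounds than this note shows. Statements on the series, on what has been measured and on what is new or still open speak of the compounds shown alone.

In a functional assay on RS4-11 cells (Homo sapiens) for antiproliferative activity, read by MTT assay, with a stated time of 48 h (on this read-out lower numbers stand for an effect already at smaller amounts and higher numbers for an effect only at larger amounts of compound), compound 1 `COC(=O)c1[nH]c2cc(OC)ccc2c1-c1ccc(Br)cc1` gives 200 nM. Compound 2 `CCc1c(C(=O)OC)[nH]c2cc(OC)ccc12` reads > 100000 nM, which is a limit. Compound 3 `COC(=O)c1[nH]c2cc(OC)ccc2c1C1CCCCC1` reads > 100000 nM, also only a limit, so it has no number to start from. Compound 4 `COC(=O)c1[nH]c2cc(OC)ccc2c1Cc1ccccc1` carries benzyl in place of cyclohexyl on an aromatic carbon. Within the data shown here, the steps that bear on this are an at least 500-fold higher number from compound 1 to compound 2 (2.69 log units; beyond the scatter) and an at least 500-fold higher number from compound 1 to compound 3 (2.69 log units; beyond the scatter), both large, with ethyl and cyclohexyl each replacing 4-bromophenyl. Benzyl restores an aromatic ring, which among the groups measured here only compound 1 carries, so partial recovery is expected. The expected change is an at least 3.3-fold lower number from compound 3 to compound 4 (0.52 log units; beyond the scatter), towards a lower number, though another limit reading remains quite possible. For compound 4 the estimate is 30000 nM, with an expected range from 2000 nM to 100000 nM.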

Compound 4, half-maximal effective concentration: 61600 nM
Estimate against measurement, compound 4: 2.1-fold (0.31 log units) below; the range from low to high includes it.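

In this assay compound 4 gives a measured number where cyclohexyl and ethyl gave only limits, so benzyl at this position gives a readable but weak effect. Still a 310-fold higher number from compound 1 to compound 4 (2.49 log units; beyond the scatter) remains large, so benzyl does not stand in for 4-bromophenyl. The gains read only as floors: an at least 1.6-fold lower number from compound 3 to compound 4 (0.21 log units; that floor lies within the scatter) and an at least 1.6-fold lower number from compound 2 to compound 4 (0.21 log units; that floor lies within the scatter) both rest on a floor within the scatter.

As far as these compounds go, whether the loss from compound 1 follows the added saturated carbon or the missing bromine stays open, and plain phenyl on the same aromatic carbon would separate the two. How far compounds 2 and 3 truly lie from compound 4 also stays open: the limit of > 100000 nM in this assay, at which 2 of the 4 values shown sit.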